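From a Fluorophenoxy Ether to a Benzyl Group

A few compounds are considered here, and "the series" means these few. Any claim that something is new, unique, unknown or untested is made for them only; others in the source may bear on it.

Of the compounds shown here, three have been measured so far. In a functional assay for inhibition, with Homo sapiens as the target (on this read-out lower numbers stand for tighter binding and higher numbers for weaker binding), compound 1 `O=C(O)CC/C=C\CC1COC(c2ccccc2Cl)OC1c1cccnc1` gives 759 nM. Compound 2 `Cc1ccc(C#N)c(OC(C)(C)C2OCC(C/C=C\CCC(=O)O)C(c3cccnc3)O2)c1` gives 15.9 nM in this assay, and compound 3 `CC(C)(Oc1ccc(F)cc1)C1OCC(C/C=C\CCC(=O)O)C(c2cccnc2)O1` gives 120 nM. Compound 3 therefore stands second highest of the three numbers, well separated from both neighbours. Compound 4 `CC(C)(Cc1ccccc1)C1OCC(C/C=C\CCC(=O)O)C(c2cccnc2)O1` has not yet been measured; it differs from compound 3 in one place: benzyl in place of 4-fluorophenoxy on a saturated chain carbon bound to two saturated chain carbons and a saturated ring carbon. Among the measured compounds shown here, the only measured step, a 7.5-fold higher number from compound 2 to compound 3 (0.88 log units; beyond the scatter), changed the aromatic group while keeping the oxygen, so it bears on this change only loosely. A modest step is expected for compound 4, most likely towards a somewhat higher number, a 1.7-fold higher number from compound 3 to compound 4 (0.22 log units; within the scatter) in this assay. Compound 4 is estimated at 200 nM, within 60 nM to 700 nM.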

Compound 4, dissociation constant: 513 nM
For compound 4 the middle estimate is 2.6-fold (0.41 log units) below the measured one; measured number inside the range.
By their numbers in this assay, from the lowest: compound 2; then compound 3; then compounds 4 and 1 (each within the scatter of the next).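

On this saturated chain carbon, the oxygen-linked aromatic group matters: in this assay, benzyl in place of 4-fluorophenoxy gives a 4.3-fold higher number from compound 3 to compound 4 (0.63 log units; beyond the scatter), and benzyl in place of the 2-cyano-5-methylphenyl ether gives a larger change, a 32-fold higher number from compound 2 to compound 4 (1.51 log units; beyond the scatter). Placing 1-benzyl-1-methylethyl instead of 2-chlorophenyl on a saturated ring carbon gives a 1.5-fold lower number from compound 1 to compound 4 (0.17 log units; within the scatter), so these two groups cannot be told apart here. No measurement available explains these results. As far as these compounds go, the step to compound 4 removes both the oxygen and the fluorine, so their separate contributions remain open. Unsubstituted phenoxy at this position would separate them.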